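A few compounds are considered here, and "the series" means these few. Any claim that something is new, unique, unknown or untested is made for them only; others in the source may bear on it.

In an ADME assay on MT4 cells (Homo sapiens) for cytotoxicity, read by MTT assay, with a stated time of 5 days (a lower number here means that less compound is tolerated, a higher number that more compound is tolerated), compound 3 (`Cc1cc(C)cc(S(=O)(=O)c2c(C(=O)N[C@H]3CCN(Cc4ccccc4F)C3)[nH]c3ccc(Cl)cc23)c1`) gives 215000 nM, the highest of three numbers, ahead of compound 1 (`Cc1cc(C)cc(S(=O)(=O)c2c(C(=O)N[C@@H]3CCN(Cc4cccnc4)C3)[nH]c3ccc(Cl)cc23)c1`) at 36500 nM and compound 2 (`Cc1cc(C)cc(S(=O)(=O)c2c(C(=O)N[C@@H]3CCN(S(C)(=O)=O)C3)[nH]c3ccc(Cl)cc23)c1`) at 24000 nM. Compound 4 (`Cc1cc(C)cc(S(=O)(=O)c2c(C(=O)N[C@H]3CCN(S(C)(=O)=O)C3)[nH]c3ccc(Cl)cc23)c1`) differs from compound 3 by methylsulfonyl in place of 2-fluorobenzyl on an amine nitrogen in a ring. Among the measured compounds shown here, the one measured step that bears on this is a 1.5-fold lower number from compound 1 to compound 2 (0.18 log units; within the scatter), where methylsulfonyl replaced (pyridin-3-yl)methyl and the change stayed within the scatter. It does not start from 2-fluorobenzyl, however. Compound 2, at 24000 nM, carries the same methylsulfonyl with the opposite configuration at the ring atom that bears a large group, so a clear fall in this assay is expected. The estimated change is a 5.4-fold lower number from compound 3 to compound 4 (0.73 log units; beyond the scatter). For compound 4 the expected value is 40000 nM, within an estimated range from 15000 nM to 150000 nM.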

Compound 4, half-maximal cytotoxic concentration: 29900 nM
Estimate against measurement, compound 4: 1.3-fold (0.13 log units) above; measured number inside the range.
By their numbers in this assay, from the lowest: compounds 2, 4 and 1 (each within the scatter of the next); then compound 3.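

In this assay, among the compounds shown here, methylsulfonyl in place of 2-fluorobenzyl on the amine nitrogen in the ring gives a 7.2-fold lower number from compound 3 to compound 4 (0.86 log units; beyond the scatter), the first step at this nitrogen that lies beyond the scatter. Changing the configuration at the saturated ring carbon gives only a 1.2-fold higher number from compound 2 to compound 4 (0.10 log units; within the scatter), a comparison that isolates configuration alone: the fact that compounds 2 and 4 differ only in the configuration as drawn. Methylsulfonyl and (pyridin-3-yl)methyl also stay within the scatter in this configuration comparison, with a 1.2-fold lower number from compound 1 to compound 4 (0.09 log units; within the scatter), so compound 3 alone stands apart. The compounds shown leave open whether an unsubstituted benzyl or an acetyl on this nitrogen would give a number near that of compound 3, and whether 2-fluorobenzyl would keep that number in the opposite configuration.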